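Chloro to Bromo in a Two-Compound Series

The compounds below may be only part of what the source reports. "The series", "measured", "known", "first", "only" and "open" are said of these compounds alone.

In a functional assay on MCF7 cells (Homo sapiens) for antiproliferative activity, read by MTT assay, with a stated time of 48 h (a lower number here means a stronger inhibitor, a higher number a weaker inhibitor), compound 1 `Cc1ccc(C(=O)/C=C/c2cc(Cl)cc(Cl)c2Oc2c([N+](=O)[O-])cc(C(F)(F)F)cc2[N+](=O)[O-])cc1` gives 0.7 ug/mL and compound 2 `O=C(/C=C/c1cc(Cl)cc(Cl)c1Oc1c([N+](=O)[O-])cc(C(F)(F)F)cc1[N+](=O)[O-])c1ccc(Cl)cc1` gives 4.54 ug/mL, so compound 2 holds the higher, weaker number of the two. Compound 3 `O=C(/C=C/c1cc(Cl)cc(Cl)c1Oc1c([N+](=O)[O-])cc(C(F)(F)F)cc1[N+](=O)[O-])c1ccc(Br)cc1` differs from compound 2 by a single exchange, bromo in place of chloro on an aromatic carbon. Within the data shown here, the only measured step bearing on this is a 6.5-fold higher number from compound 1 to compound 2 (0.81 log units; beyond the scatter), a modest change of methyl to chloro that involves no bromo. The expectation therefore stays close to compound 2, with no clear direction. In this assay the expected change, within the scatter, is a 1.1-fold lower number from compound 2 to compound 3 (0.05 log units; within the scatter). Compound 3 is estimated at 4 ug/mL, with an expected range of 1.7 ug/mL to 9.5 ug/mL.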

Compound 3, half-maximal inhibitory concentration: 2.6 ug/mL
Beside the measured number, compound 3's estimate is 1.5-fold (0.19 log units) above it; low and high end bracket the measured number.
By their numbers in this assay, from the lowest: compound 1; then compounds 3 and 2 (each within the scatter of the next).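

The step of a 1.7-fold lower number from compound 2 to compound 3 (0.24 log units; within the scatter) shows that in this assay bromo and chloro cannot be told apart at this position, para to a large group. The step of a 3.7-fold higher number from compound 1 to compound 3 (0.57 log units; beyond the scatter) lies beyond the scatter, so the methyl of compound 1 now stands apart from both halogens rather than from chloro alone. Nothing available explains this difference.

Going by these compounds, whether the methyl's advantage is particular to that group remains open. An ethyl, a methoxy or an amine at the same position would test this, and so would fluoro for the halogen side.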